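Extending the Thiol Arm: From Compound 2 to Compound 3

The source may hold more compounds than are shown below. What is called first, only, known or untested is meant among the compounds shown, and "the series" means these compounds.

Measured so far in an assay for inhibition of Polyunsaturated fatty acid 5-lipoxygenase (Rattus norvegicus); on this read-out higher numbers stand for weaker inhibition and lower numbers for stronger inhibition:
compound 1 `CCCCC/C=C\C/C=C\C/C=C\C=C\C(S)CCCC(=O)O`: 7600 nM
compound 2 `CCCCC/C=C\C/C=C\C/C=C\C=C\C(CS)CCCC(=O)O`: 11000 nM

Of the two numbers, compound 2 gives the larger, though only by a 1.4-fold higher number from compound 1 to compound 2 (0.16 log units; within the scatter), a step within the scatter. Compound 3 `CCCCC/C=C\C/C=C\C/C=C\C=C\C(CCCS)CCCC(=O)O` carries the same chain and acid but differs from compound 2 by 2-sulfanylethyl in place of sulfanyl on a saturated chain carbon, two bonds along the chain from a double-bonded chain carbon. Among the compounds with values here, the one measured step, a 1.4-fold higher number from compound 1 to compound 2 (0.16 log units; within the scatter), also moved the sulfur outward by a carbon and changed nothing beyond the scatter, so no step beyond the scatter is expected here either. For compound 3 the estimate in this assay is 13000 nM, between 5000 nM and 35000 nM, a step of a 1.2-fold higher number from compound 2 to compound 3 (0.07 log units; within the scatter).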

Compound 3, half-maximal inhibitory concentration: 36000 nM
The estimate for compound 3 lay 2.8-fold (0.44 log units) below the measured number; the measured number lies above the stated range.
By their numbers in this assay, from the lowest: compounds 1 and 2 (each within the scatter of the next); then compound 3.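

In this assay, arm length at this saturated chain carbon now makes a difference beyond the scatter: going from sulfanylmethyl to 3-sulfanylpropyl gives a 3.3-fold higher number from compound 2 to compound 3 (0.51 log units; beyond the scatter), and the full change from sulfanyl to 3-sulfanylpropyl gives a 4.7-fold higher number from compound 1 to compound 3 (0.68 log units; beyond the scatter). The shorter step between compound 1 and compound 2 had shown no such change, so weaker inhibition appears only with the longest arm. Nothing available explains this result. Still open, going by these compounds, is how an arm ending in an amine or a hydroxyl group would compare, and whether a longer chain, such as 4-sulfanylbutyl, would weaken inhibition further.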